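Fluoro to chloro on the shared core of compound 3

The source may report more compounds than this note shows. Statements on the series, on what has been measured and on what is new or still open speak of the compounds shown alone.

In a functional assay on KYSE-70 cells for antiproliferative activity against KYSE-70 cell line (Homo sapiens), read by MTT assay, with a stated time of 72 h (on this read-out lower numbers stand for stronger inhibition and higher numbers for weaker inhibition), compound 3 (`O=C(Nc1cc(F)cc(F)c1)c1cc(=O)[nH]c2cc(F)ccc12`) gives > 20000 nM, which is a limit of the assay and not a number. Compound 2 (`O=C(Nc1cccc(F)c1)c1cc(=O)[nH]c2cc(F)ccc12`) gives > 20000 nM, which is also a limit. Compound 1 (`O=C(Nc1cc(F)cc(F)c1)c1cc(=O)[nH]c2cc(Br)ccc12`) gives a true number, 10700 nM.

Compound 4 (`O=C(Nc1cc(F)cc(F)c1)c1cc(=O)[nH]c2cc(Cl)ccc12`) departs from compound 3 by a single exchange, chloro in place of fluoro on an aromatic carbon. The measured step closest to this exchange swaps bromo for fluoro, and it is an at least 1.8-fold higher number from compound 1 to compound 3 (0.27 log units; that floor lies within the scatter). The other measured step, a different exchange, is a step that the two limits leave unreadable from compound 2 to compound 3, so it offers no guide to size. Only the bromo exchange therefore bears on compound 4, and it gives no firm size.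

The expected change is an at least 1.3-fold lower number from compound 3 to compound 4 (0.12 log units; that floor lies within the scatter), which means no clear shift beyond the scatter. The estimate for compound 4 is 15000 nM, with an expected range from 8000 nM to 30000 nM.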

Compound 4, half-maximal inhibitory concentration: 9000 nM
For compound 4 the middle estimate is 1.7-fold (0.22 log units) above the measured one, and the stated range covers the measured number.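

In this assay, going by these compounds alone, chloro in place of fluoro at this position gives the first step on the shared core that is readable as lying beyond the scatter: an at least 2.2-fold lower number from compound 3 to compound 4 (0.34 log units; beyond the scatter). Chloro and bromo at this position, by contrast, cannot be told apart, with a 1.2-fold lower number from compound 1 to compound 4 (0.08 log units; within the scatter). The size of the fluoro step remains a floor and no more, since compound 3 carries a limit of the assay and not a number: the limit of > 20000 nM in this assay, at which 2 of the 4 values shown sit.

The compounds shown leave open how a methoxy group or an amine at this position would read, and whether any group here can take the number well past that of chloro and bromo. From the compounds shown here alone, it also remains open whether chloro on the core of compound 2 would give a step of similar size.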